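The source may report more compounds than this note shows. Statements on the series, on what has been measured and on what is new or still open speak of the compounds shown alone.

Of the compounds shown here, three have been measured in an assay on HEK293 cells for positive allosteric modulation of metabotropic glutamate receptor 2 (Rattus norvegicus), read by thallium flux, with a stated time of 2.5 min; on this read-out higher numbers stand for an effect only at larger amounts of compound and lower numbers for an effect already at smaller amounts. Compound 1, `Cc1c(OCCCCOc2ccc(C(=O)O)cc2Cl)ccc(C(=O)CC2CCCC2)c1O`, gives 237 nM, the highest of the three numbers. Among the measured compounds shown here, compound 3, `Cc1c(OCCCCOc2cccc(C(=O)O)c2)ccc(C(=O)CC(C)C)c1O`, gives 222 nM in this assay, a number that lies within the usual scatter of the one for compound 1, so the two cannot be told apart. Compound 2, `CCCC(=O)c1ccc(OCCCCOc2cc(C(=O)O)ccc2OC)c(C)c1O`, gives 103 nM in this assay, and its gap from compound 1 lies beyond the scatter. No two of these compounds differ in only one place, so no measured step links any pair of them.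

Compound 4, `Cc1c(OCCCCOc2ccc(C(=O)O)cc2F)ccc(C(=O)CC2CCCC2)c1O`, is built from compound 1 by a single change: fluoro in place of chloro on an aromatic carbon. Everything else in the structure is kept. For the measured compounds named here, nothing among the measured compounds shows what this swap does in this assay, so the expectation rests on the change alone, one halogen traded for another, which is expected to move the number little, if at all, perhaps slightly toward higher values. The step expected here is a 1.3-fold higher number from compound 1 to compound 4 (0.10 log units; within the scatter), small enough to sit within the scatter. Compound 4 is therefore expected to give about 300 nM in this assay, with a likely range from 120 nM to 800 nM.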

Compound 4, half-maximal effective concentration: 639 nM
The estimate for compound 4 lay 2.1-fold (0.33 log units) below the measured number, and the stated range covers the measured number.
By their numbers in this assay, from the lowest: compound 2; then compounds 3 and 1 (each within the scatter of the next); then compound 4.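

Trading one halogen for the other at this position is not a neutral change in this assay: going from 4-carboxy-2-chlorophenyl to 4-carboxy-2-fluorophenyl gives a 2.7-fold higher number from compound 1 to compound 4 (0.43 log units; beyond the scatter), a modest step but one beyond the scatter. Among the compounds shown here, this is the only step in the set that isolates a single place, as the earlier compounds differ from each other in more than one, so it gives the first direct reading on this position: with the rest of compound 1 held fixed, chloro goes with an effect at smaller amounts of compound than fluoro does. Nothing available explains why these two halogens differ here.

Whether this place needs a halogen at all remains open, as the compounds shown do not reveal how bromo, a methyl group or a nitrile would compare with chloro and fluoro at the same carbon. On these data alone, it is also open whether chloro would still give the lower number than fluoro with a different chain on the ketone carbonyl, since this swap is read on the core of compound 1 alone.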